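The source may report more compounds than this note shows. Statements on the series, on what has been measured and on what is new or still open speak of the compounds shown alone.

Measured so far:
compound 1 `Oc1ccccc1-c1cc(-c2ccco2)cc(-c2ccccc2O)n1`: 89.1%
compound 2 `Oc1ccccc1-c1cc(-c2ccccn2)cc(-c2ccccc2O)n1`: 0.8%

In an assay on isolated protein for inhibition of DNA topoisomerase 1 (Homo sapiens), with a stated time of 30 min, tested at 100 uM (on this read-out lower numbers stand for a weaker effect and higher numbers for a stronger effect at the one concentration tested), compound 2 gives 0.8%, the lower of the two numbers here; compound 1 gives 89.1%. Among the measured compounds shown here, the one measured step, a number 88.3 percentage points lower from compound 1 to compound 2 (beyond the scatter), exchanges the whole ring and does not test the present change. Compound 3 `Oc1ccccc1-c1cc(-c2cccnc2)cc(-c2ccccc2O)n1` differs from compound 2 by pyridin-3-yl in place of pyridin-2-yl on an aromatic carbon. For the measured compounds named here, no step bears directly on this, so a partial recovery is expected but with wide uncertainty, estimated as a number 29.2 percentage points higher from compound 2 to compound 3 (beyond the scatter). Compound 3 is expected to give 30%, within 0% to 75%.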

Compound 3, a percentage reported as inhibition, at one concentration (the size of the read-out at that concentration, not a potency): 66.4%
For compound 3 the middle estimate is 36.4 percentage points below the measured one, and the stated range covers the measured number.
By their numbers in this assay, from the lowest: compound 2; then compound 3; then compound 1.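

Exchanging pyridin-2-yl for pyridin-3-yl keeps the same ring and atom counts at this position, yet gives a number 65.6 percentage points higher from compound 2 to compound 3 (beyond the scatter) and shows that the near-total loss in compound 2 does not extend to every pyridine attachment. Against furan-2-yl, pyridin-3-yl shows a number 22.7 percentage points lower from compound 1 to compound 3 (beyond the scatter) and so recovers much, but not all, of the effect.

Where pyridin-4-yl, phenyl or thiophen-2-yl would fall at this position remains open. No supporting evidence explains either step.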